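The source may hold more compounds than are shown below. What is called first, only, known or untested is meant among the compounds shown, and "the series" means these compounds.

Compounds measured so far:
Compound 1, `CN1CCN(c2nc(Nc3ccc(C#N)c(C(F)(F)F)c3)nc(Oc3ccnc4ccccc34)n2)CC1`, in a functional assay on DU-145 cells (Homo sapiens) for cytotoxicity, read by sulforhodamine B assay, with a stated time of 48 h (on this read-out higher numbers stand for weaker inhibition of growth and lower numbers for stronger inhibition of growth), gives > 100000 nM, which is a limit of the assay and not a number.
Compound 2, `COc1ccc(CN2CCN(c3nc(Nc4ccc(C#N)c(C(F)(F)F)c4)nc(Oc4ccnc5ccccc45)n3)CC2)c(OC)c1OC`, in this assay gives > 100000 nM, likewise a limit rather than a number.

Among the measured compounds shown here, compound 1 therefore stands at the limit of this assay, and so does the only other compound measured; both values sit at the limit of > 100000 nM in this assay, at which 2 of the 2 values shown sit. For the measured compounds named here, the single measured step, a step that the two limits leave unreadable from compound 1 to compound 2, cannot be read, since both of its ends are limits, and it tells nothing about the size or direction of any change.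

Compound 3, `N#Cc1ccc(Nc2nc(Oc3ccnc4ccccc34)nc(N3CCCCC3)n2)cc1C(F)(F)F`, differs from compound 1 in one place: piperidin-1-yl in place of 4-methylpiperazin-1-yl on an aromatic carbon. Going by the values given here, no measured step touches this position of the shared core, so there is no evidence on which to size the change. With compound 1 resting at the limit and no readable step to draw on, compound 3 is expected to remain at or near that limit, with the step of a number no higher from compound 1 to compound 3 (the limit leaves the size open) expected to be small or unreadable. The estimate for compound 3 in this assay is 100000 nM, in a range from 20000 nM to 400000 nM.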

Compound 3, concentration for total growth inhibition: > 100000 nM
Compound 3 was reported as a limit; the forecaster's own chance of this, stated with the estimate: 70%; the middle value sits exactly at the limit.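

The step from compound 1 to compound 3 cannot be read, since both of its ends are limits and not numbers in this assay: the limit of > 100000 nM in this assay, at which 3 of the 3 values shown sit.

The compounds shown leave open how far any of their true values lies from that limit, and whether any change to the shared core would give a readable inhibition of growth in this assay.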